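Adding one carbon to the sulfur chain of compound 3

This account rests on a few compounds, and the source may have more. Where it says the series, first, only, none or still open, it means among the compounds named here.

In an ADME assay on MT4 cells (Homo sapiens) for activation, read by MTT assay (on this read-out lower numbers stand for higher toxicity in this test and higher numbers for lower toxicity in this test), compound 3 `CCCSc1nc(C(CC)c2c(F)cccc2Cl)c(C)c(=O)[nH]1` gives > 3000 nM, which is a limit and not a number. Compound 2 `CCC(c1nc(SC(C)C)[nH]c(=O)c1C)c1c(F)cccc1Cl` gives > 3000 nM, which is also a limit. Compound 1 `CCCCSc1nc(Cc2c(F)cccc2Cl)c(C)c(=O)[nH]1` gives > 73000 nM, which is a limit as well. No exact reading is therefore available among these compounds, and compound 3 has no number from which to measure a change.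

Compound 4 `CCCCSc1nc(C(CC)c2c(F)cccc2Cl)c(C)c(=O)[nH]1` differs from compound 3 by one change on the sulfur chain, (methyl in place of hydrogen on a saturated chain carbon, three bonds along the chain from a sulfur). This is methyl in place of hydrogen on a saturated chain carbon, three bonds along the chain from a sulfur, so that propyl becomes butyl.

For the measured compounds named here, only one measured step bears on this chain: a step that the two limits leave unreadable from compound 2 to compound 3, with propyl in place of isopropyl on a sulfur. That step offers no size or direction to carry forward. With no readable precedent, no shift beyond the usual scatter can be argued, and the expected change is a step that the limit leaves unreadable from compound 3 to compound 4, a tentative figure. The assay may well report only a limit again. For compound 4 the estimated value is 10000 nM, with an expected range of 3000 nM to 73000 nM.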

Compound 4, half-maximal cytotoxic concentration: > 3000 nM
Compound 4: a limit, no number (the forecaster's own chance of this, stated with the estimate: 70%); the middle value lies beyond the limit too.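

In this assay compound 4 gives > 3000 nM, which is a limit and not a number, and its steps from compound 1, compound 2 and compound 3 cannot be read in size or direction. The compounds shown carry no exact value, leaving open whether propyl to butyl on the sulfur changes the reading in this assay at all.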